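The source may hold more compounds than are shown below. What is called first, only, known or untested is meant among the compounds shown, and "the series" means these compounds.

The measured compounds are:

Compound 1, `CCOC(=O)c1cccc(-c2cnc(C(=O)CCc3ccc(-c4ccccc4)cc3)o2)n1`, gives 3 nM in an assay for inhibition of Fatty-acid amide hydrolase 1 (Rattus norvegicus); on this read-out higher numbers stand for weaker inhibition and lower numbers for stronger inhibition.
Compound 2, `N#Cc1cccc(-c2cnc(C(=O)CCc3ccc(COc4ccccc4)cc3)o2)n1`, gives 0.56 nM in this assay.
Compound 3, `COC(=O)c1cnc(C(=O)CCc2ccc(Oc3ccccc3)cc2)o1`, gives 1.7 nM in this assay.

Among these three numbers compound 3 stands second highest. Its nearest neighbour is compound 1, whose number is somewhat higher, a gap that lies within the usual scatter of repeated measurements, so no order between compound 3 and compound 1 can be read from it. Compound 2 is furthest away, with a lower number that lies beyond the scatter, and the two values show compound 2 to be the stronger inhibitor of the pair.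

Compound 4, `CN(C)C(=O)c1cnc(C(=O)CCc2ccc(Oc3ccccc3)cc2)o1`, is not yet measured. It differs from compound 3 in one place: dimethylamino in place of methoxy on a carbonyl carbon. Going by the values given here, no pair of measured compounds carries this difference, so there is no measured step to lean on. Compound 4 is expected to give about 3 nM, with a range from 0.8 nM to 12 nM. The estimated step of a 1.8-fold higher number from compound 3 to compound 4 (0.25 log units; within the scatter) is expected to be small, a slightly higher number at most, and not beyond the scatter.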

Compound 4, inhibition constant: 5.4 nM
Compound 4: middle estimate off by 1.8-fold (0.26 log units), on the low side; the measured number falls inside the stated range.
By their numbers in this assay, from the lowest: compound 2; then compounds 3, 1 and 4 (each within the scatter of the next, the first and the last beyond it).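

In this assay, dimethylamino in place of methoxy on a carbonyl carbon gives a 3.2-fold higher number from compound 3 to compound 4 (0.50 log units; beyond the scatter), the first step measured between two compounds that differ in one place. This place is therefore not indifferent to the change: the methoxycarbonyl group of compound 3 gives the stronger inhibitor of the pair, although the step is modest and the dimethylcarbamoyl group of compound 4 still leaves a potent inhibitor. Nothing available explains this difference.

The compounds shown leave open how a carboxylic acid, an unsubstituted carboxamide or a pyrrolidine amide on this carbonyl carbon would compare with these two groups. They also leave open whether the same change would have a similar effect where the rest of the molecule differs, as it does in compound 1 and compound 2.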